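Substituent changes on the indole of a terpene ester series

A few compounds are considered here, and "the series" means these few. Any claim that something is new, unique, unknown or untested is made for them only; others in the source may bear on it.

Measured compounds:
Compound 1, `COC(=O)[C@@]1(C)CCC=C2[C@@H]1CC[C@@H](C)[C@]2(C)Cc1c[nH]c2ccc(C)cc12`, 18000 nM
Compound 2, `COC(=O)[C@@]1(C)CCC=C2[C@@H]1CC[C@@H](C)[C@]2(C)Cc1c[nH]c2ccc(Br)cc12`, 16000 nM
Compound 3, `COC(=O)[C@@]1(C)CCC=C2[C@@H]1CC[C@@H](C)[C@]2(C)Cc1c(C)[nH]c2ccc(C)cc12`, 25000 nM

All three measurements come from a functional assay on HBL-100 cells (Homo sapiens) for inhibition, read by sulforhodamine B assay, with a stated time of 48 h; a lower number here means a stronger inhibitor of growth, a higher number a weaker inhibitor of growth. The numbers for compound 1, compound 2 and compound 3 lie close together: compound 3 gives the largest of the three numbers, but its gaps to compound 1 and to compound 2 are both within the scatter, so no ranking among the three follows from these data.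

Compound 4, `COC(=O)[C@@]1(C)CCC=C2[C@@H]1CC[C@@H](C)[C@]2(C)Cc1c(C)[nH]c2ccc(OC)cc12`, has not been measured in this assay. It differs from compound 3 in one place: methoxy in place of methyl on an aromatic carbon.

Among the measured compounds shown here, two measured steps bear on this change, as both also exchange a substituent on an aromatic carbon. The step of a 1.1-fold lower number from compound 1 to compound 2 (0.05 log units; within the scatter) and the step of a 1.4-fold higher number from compound 1 to compound 3 (0.14 log units; within the scatter) are both within the scatter. Nothing in the measured steps points to an effect of swapping a small aromatic substituent, so the step from compound 3 to compound 4 is expected to stay within the scatter as well, in no particular direction: the expected step is a 1.1-fold lower number from compound 3 to compound 4 (0.06 log units; within the scatter).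

For compound 4 in this assay the estimate is 22000 nM, with a range from 9000 nM to 55000 nM.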

Compound 4, concentration for 50% growth inhibition: 16000 nM
Compound 4: middle estimate off by 1.4-fold (0.14 log units), on the high side; measured number inside the range.
By their numbers in this assay, from the lowest: compounds 2, 4, 1 and 3 (each within the scatter of the next).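

In this assay, methoxy in place of methyl on this aromatic carbon, meta to a fused ring and para to a fused ring, gives a 1.6-fold lower number from compound 3 to compound 4 (0.19 log units; within the scatter). Earlier steps had only exchanged methyl for bromo at this carbon or added a methyl elsewhere on the indole, whereas this change enters an oxygen and a hydrogen-bond acceptor and still leaves the number within the scatter, so the tolerance seen so far at this carbon now spans methyl, bromo and methoxy, with no compound shown going against it. That reading rests on a single step on the background of compound 3, which carries the additional methyl, and no measurement explains the small size of this step.

Open, from the compounds shown here alone, is whether any group at this carbon can move the number beyond the scatter, for example an amine, a carboxylic acid or a longer chain such as butoxy. Going by these compounds, all four compounds also keep the methyl ester and the shared core, so the effect of a carboxylic acid or an amide in place of that ester remains unknown.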